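Shortening the amide substituent: compound 3 to compound 4

A few compounds are considered here, and "the series" means these few. Any claim that something is new, unique, unknown or untested is made for them only; others in the source may bear on it.

Measured in a physicochemical assay for lipophilicity, at pH 7.4; a higher number here means a more lipophilic compound, a lower number a more polar compound:
Compound 1 `CNC(=O)c1cc(C(=O)N[C@H]2[C@@H]3C[C@H](O)C[C@@H]32)cc2c1OC[C@@]2(C)c1ccccc1`: 3.7
Compound 2 `CCC(=O)N1C[C@@H]2[C@H](C1)[C@H]2NC(=O)c1cc(C(=O)NC)c2c(c1)[C@H](c1ccccc1)CO2`: 3.4
Compound 3 `CNC(=O)c1cc(C(=O)N[C@@H]2C[C@H]2C)cc2c1O[C@H](CF)[C@H]2c1ccccc1`: 4.5

Compound 3 gives 4.5, the highest of the three numbers, and both compound 1 and compound 2 lie lower by more than the scatter. Compound 4 `CNC(=O)c1cc(C(=O)NC)c2c(c1)[C@H](c1ccccc1)[C@@H](CF)O2` is not yet measured. Its difference from compound 3 is methyl in place of 2-methylcyclopropyl on an amide-type nitrogen. Among the measured compounds shown here, no measured pair differs in one place only, so the expectation rests on the structural change alone. A fall beyond the scatter is expected, estimated as a number 0.90 log units lower from compound 3 to compound 4 (beyond the scatter). For compound 4 the estimated value is 3.6, with a range of 3.2 to 4.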

Compound 4, distribution coefficient: 3.3
Compound 4: middle estimate off by 0.30 log units, on the high side, and the stated range covers the measured number.
By their numbers in this assay, from the lowest: compounds 4, 2 and 1 (each within the scatter of the next, the first and the last beyond it); then compound 3.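

Among the compounds shown here, with the first pair differing in one place only, this assay puts a size on this amide substituent: methyl in place of 2-methylcyclopropyl on an amide-type nitrogen gives a number 1.20 log units lower from compound 3 to compound 4 (beyond the scatter) as a large step. The group that leaves carries a three-membered carbon ring and two defined stereocentres, while hydrogen-bond donor and acceptor counts stay at zero on both sides. No available evidence bears on the origin of this step.

Still open, as far as these compounds go, is whether ethyl or unsubstituted cyclopropyl on this nitrogen would read nearer compound 3 or compound 4. Also open, from the compounds shown here alone, is how an amine or a carboxylic acid on this substituent would read.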